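A Fluorine Swap on a Cyclopropane Diamide Series

This account rests on a few compounds, and the source may have more. Where it says the series, first, only, none or still open, it means among the compounds named here.

Measured so far in a functional assay on T47D cells (Homo sapiens) for inhibition, read by CCK-8 assay, with a stated time of 72 h, tested at 10 uM; a lower number here means less inhibition of growth, a higher number more inhibition of growth at the concentration tested:
Compound 1 `Cc1cccc(NC(=O)C2(C(=O)Nc3ccc(Nc4ncc5cc(C(=O)N(C)C)n(C6CCCC6)c5n4)cc3)CC2)c1`: 95.3%
Compound 2 `COc1ccc(NC(=O)C2(C(=O)Nc3ccc(Nc4ncc5cc(C(=O)N(C)C)n(C6CCCC6)c5n4)cc3)CC2)cc1`: 96.1%

Only these two compounds have been measured, and their values lie within the scatter of each other, so compound 1 stands level with compound 2. Compound 3 `CN(C)C(=O)c1cc2cnc(Nc3ccc(NC(=O)C4(C(=O)Nc5ccccc5F)CC4)cc3)nc2n1C1CCCC1` is still unmeasured. It differs from compound 1 by one change, 2-fluorophenyl in place of 3-methylphenyl on an amide-type nitrogen. Going by the values given here, one measured step bears on this, as it changes the group at the same place: a number 0.8 percentage points higher from compound 1 to compound 2 (within the scatter). Among the compounds with values here, that single step is small, and no measured compound carries 2-fluorophenyl, so the evidence is thin. No shift beyond the scatter is therefore expected in this assay, and the estimated step is a number 1.3 percentage points lower from compound 1 to compound 3 (within the scatter). For compound 3 the estimated value is 94%, with an expected range from 84% to 99%.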

Compound 3, percent growth inhibition at one concentration: 97.8%
Compound 3: middle estimate off by 3.8 percentage points, on the low side, and the stated range covers the measured number.
By their numbers in this assay, from the lowest: compounds 1, 2 and 3 (each within the scatter of the next).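

Going by these compounds alone, both swaps to 2-fluorophenyl on the amide-type nitrogen leave compound 3 level with the earlier compounds in this assay with a number 2.5 percentage points higher from compound 1 to compound 3 (within the scatter) and a number 1.7 percentage points higher from compound 2 to compound 3 (within the scatter) as the two steps. The earlier pair showed this only for two carbon-ring groups carrying methyl or methoxy, whereas this result extends it to a fluorine-bearing ring with the same heavy-atom count as 3-methylphenyl, so all three aryl groups at this place read alike at this one concentration. No measurement shown here explains why these groups sit level.

From the compounds shown here alone, it remains open whether any group on this nitrogen would move the number beyond the scatter, for instance a cyclohexyl ring, a pyridine ring or a chain ending in an amine. Nor can a single concentration tell whether the three compounds would stay level at lower concentrations.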